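This account rests on a few compounds, and the source may have more. Where it says the series, first, only, none or still open, it means among the compounds named here.

In a functional assay on HepG2 cells (Homo sapiens) for cytotoxicity, read by MTT assay, with a stated time of 72 h (on this read-out lower numbers stand for stronger inhibition and higher numbers for weaker inhibition), compound 1 (`Cc1c(C)c2c(c(C)c1OC(=O)CCC(=O)O)CCC(C)(C(=O)NC1CC(C)(C)N([O])C(C)(C)C1)O2`) gives > 300000 nM, which is a limit of the assay and not a number. Compound 2 (`Cc1c(C)c2c(c(C)c1OC(=O)CCC(=O)O)CCC(C)(C(=O)NCC1CC(C)(C)N([O])C1(C)C)O2`) gives > 300000 nM, also a limit. Compound 1 therefore shares (the limit of > 300000 nM in this assay, at which 2 of the 3 values shown sit). Compound 3 (`Cc1c(C)c2c(c(C)c1OC(=O)CCC(=O)O)CCC(C)(C(=O)O)O2`) gives a true number, 242000 nM.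

Compound 4 (`Cc1c(C)c2c(c(C)c1OC(=O)CCC(=O)NC1CC(C)(C)N([O])C(C)(C)C1)CCC(C)(C(=O)NC1CC(C)(C)N([O])C(C)(C)C1)O2`) keeps the core of compound 1 and changes it in one place: a group of 12 heavy atoms (9 carbon, 2 nitrogen, 1 oxygen; one six-membered non-aromatic ring with 1 hetero atom) in place of one oxygen atom, on a carbonyl carbon. The closest measured comparison is the same kind of exchange, run in the opposite direction at another carbonyl carbon. There, the data show an at least 1.2-fold lower number from compound 1 to compound 3 (0.09 log units; that floor lies within the scatter), and also an at least 1.2-fold lower number from compound 2 to compound 3 (0.09 log units; that floor lies within the scatter). Both steps are known only as floors, so neither gives an exact size. Adding the group in compound 1, relative to compound 3, brought no change beyond the scatter that can be read from these values. The same is therefore expected here, with no step beyond the scatter in this assay.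

The estimated step is a number no higher from compound 1 to compound 4 (the limit leaves the size open). For compound 4 the expected value is 300000 nM, with an estimated range from 100000 nM to 600000 nM.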

Compound 4, half-maximal inhibitory concentration: 42000 nM
Compound 4: the middle estimate sits 7.1-fold (0.85 log units) above what was measured; the measured number lies below the stated range.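

In this assay, the carbonyl carbon bearing the hydroxy group proves to be a place where a change can be read: putting the six-membered ring group there in place of hydroxy gives an at least 7.1-fold lower number from compound 1 to compound 4 (0.85 log units; beyond the scatter). For the compounds shown here, the earlier steps, all at the other carbonyl carbon, showed only floors within the scatter, so compound 4 is the first case here of a change that clearly lowers the number, and it carries the ring group on both carbonyl carbons. The true size of this step stays unknown because compound 1 sits at a limit of the assay: the limit of > 300000 nM in this assay, at which 2 of the 4 values shown sit.

As far as these compounds go, whether a small amide such as the ethyl amide, or a methyl ester, would give a similar step at this carbonyl carbon stays open. So does whether the five-membered ring group of compound 2 would do the same there.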